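Hydroxy in place of trifluoromethyl: compound 2 to compound 3

This account rests on a few compounds, and the source may have more. Where it says the series, first, only, none or still open, it means among the compounds named here.

Measured so far in a functional assay on PC-3 cells (Homo sapiens) for antiproliferative activity, read by MTT assay, with a stated time of 48 h; a higher number here means a weaker inhibitor, a lower number a stronger inhibitor:

compound 1 `O=C(/C=C\Nc1ccc(O)cc1)c1cn(-c2ccccc2)nc1-c1ccc(F)cc1` — 2600 nM
compound 2 `O=C(/C=C\Nc1ccc(C(F)(F)F)cc1)c1cn(-c2ccccc2)nc1-c1ccc(Cl)cc1` — > 50000 nM, which is a limit of the assay and not a number

Compound 2 stands at the weak end of what has been measured: its result is only a limit, (the limit of > 50000 nM in this assay, at which 1 of the 2 values shown sits), so no number is known for it. Among the compounds with values here, compound 1 is the only compound of the pair with a number.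

The next compound follows from compound 2 by one change, (hydroxy in place of trifluoromethyl on an aromatic carbon), giving compound 3 `O=C(/C=C\Nc1ccc(O)cc1)c1cn(-c2ccccc2)nc1-c1ccc(Cl)cc1`, which has not been measured yet. Compound 1 carries the same hydroxy group on the same ring, and compound 1 gives 2600 nM, a number rather than a limit. On that basis compound 3 is expected to come back into the measurable range, with an expected step of an at least 12-fold lower number from compound 2 to compound 3 (1.09 log units; beyond the scatter) towards stronger inhibition, beyond the usual scatter. The estimate for compound 3 is 4000 nM, expected to lie between 1000 nM and 20000 nM.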

Compound 3, half-maximal inhibitory concentration: 4430 nM
Compound 3: the middle estimate sits 1.1-fold (0.04 log units) below what was measured; the measured number falls inside the stated range.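

Notes on the series: in this assay, hydroxy in place of trifluoromethyl on an aromatic carbon, para to a large group, gives an at least 11-fold lower number from compound 2 to compound 3 (1.05 log units; beyond the scatter), so this position can decide whether the series reads as a number at all, a sensitivity the earlier pair could not show because it differed in two places. Chloro in place of fluoro on an aromatic carbon gives a 1.7-fold higher number from compound 1 to compound 3 (0.23 log units; within the scatter), so with hydroxy present at this position the two halogens cannot be told apart in this assay. The first step has no exact size because compound 2 rests on a limit of the assay and not on a number: the limit of > 50000 nM in this assay, at which 1 of the 3 values shown sits.

As far as these compounds go, it remains open whether the difference comes from the presence of hydroxy or from the absence of trifluoromethyl; an amine, a methoxy group or a carboxylic acid on the same aromatic carbon would help separate those two readings. From the compounds shown here alone, it is also open whether the match between chloro and fluoro holds with trifluoromethyl at this position, and the step from fluoro to chloro has so far been read only with hydroxy in place.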